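Replacing the 4-(diethylamino)phenyl Group of Compound 2

The source may report more compounds than this note shows. Statements on the series, on what has been measured and on what is new or still open speak of the compounds shown alone.

In a functional assay on HOS-TE85 cells (Homo sapiens) for inhibition, read by CCK-8 assay, with a stated time of 72 h (on this read-out higher numbers stand for weaker inhibition and lower numbers for stronger inhibition), compound 1 `COc1ccccc1N1C(=O)CSC1C(=O)NCCCCc1ccccc1` gives > 1000 nM, which is a limit of the assay. Compound 2 `CCN(CC)c1ccc(N2C(=O)CSC2c2cccc(C(=O)NCCCCc3ccccc3)c2)cc1` likewise gives only a limit, > 1000 nM. Compound 3 `O=C(NCCCCn1cccn1)c1cccc(C2SCC(=O)N2c2cc(Br)ccn2)c1` is the only one of the three with a numerical reading, at 105 nM. Compound 2 therefore stands with compound 1 at the limit of > 1000 nM in this assay, at which 2 of the 3 values shown sit, and its true potency is not known.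

Compound 4 `COc1ccc(F)cc1N1C(=O)CSC1c1cccc(C(=O)NCCCCc2ccccc2)c1` keeps the rest of compound 2 and changes one group: 5-fluoro-2-methoxyphenyl in place of 4-(diethylamino)phenyl on an amide-type nitrogen in a ring. Going by the values given here, no measured pair isolates this change, so no step beyond the scatter is expected in this assay, and no direction is favoured. This expectation rests on compound 2, whose reading of > 1000 nM is a limit. The expected change is a step that the limit leaves unreadable from compound 2 to compound 4. The estimated value for compound 4 is 1200 nM, within an expected range of 300 nM to 5000 nM.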

Compound 4, half-maximal inhibitory concentration: 8.8 nM
Beside the measured number, compound 4's estimate is 140-fold (2.13 log units) above it; measured number below the stated range.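

In this assay the group on the amide-type nitrogen in a ring proves able to move the reading strongly, with an at least 110-fold lower number from compound 2 to compound 4 (2.05 log units; beyond the scatter) when 5-fluoro-2-methoxyphenyl enters in place of 4-(diethylamino)phenyl. Going by these compounds alone, no earlier pair differed in one place, so this is the first reading of any change at this position. On these data alone, compound 2 gives > 1000 nM as a limit, so the step has a lower bound and its true size stays unknown: the limit of > 1000 nM in this assay, at which 2 of the 4 values shown sit.

The compounds shown do not separate the part played by the fluorine from that of the methoxy group, and they leave open how an unsubstituted phenyl or a chlorine in place of the fluorine would read. As far as these compounds go, whether 5-fluoro-2-methoxyphenyl would give a similar step on compound 3 also remains open.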